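A few compounds are considered here, and "the series" means these few. Any claim that something is new, unique, unknown or untested is made for them only; others in the source may bear on it.

Compound 1 `CN1CCC(c2ccc(Cl)cc2)C(C[S+]([O-])CCO)C1` sits at the higher end of the two numbers recorded so far: in an assay on isolated protein for inhibition of Norepinephrine transporter (Rattus norvegicus), read by radioligand binding (on this read-out lower numbers stand for stronger inhibition and higher numbers for weaker inhibition), compound 1 gives 42 nM, while compound 2 `CN1CCC(c2ccc(Cl)cc2)C(CSCCOC(=O)c2ccccc2)C1` gives 4.5 nM, a gap between the two that lies beyond the usual scatter. Compound 3 `CN1CCC(c2ccc(Cl)cc2)C(C[S+]([O-])CC(=O)N(C)C)C1` has not yet been measured in this assay. It differs from compound 1 by a single change, (dimethylcarbamoyl in place of hydroxymethyl on a saturated chain carbon bound to a sulfur); cut one bond further out, the same difference reads as 2-hydroxyethyl giving way to (dimethylcarbamoyl)methyl. Within the data shown here, no pair of measured compounds differing in just one place is available, so the size of this step cannot be read off directly. Among the measured compounds shown here, the only hint is that compound 2, which carries a larger group on its chain, gives the lower number 4.5 nM. Compound 3 is therefore expected to move by a 1.7-fold lower number from compound 1 to compound 3 (0.23 log units; within the scatter) relative to compound 1, a step that may not exceed the scatter. The estimate for compound 3 is 25 nM, within 8 nM to 80 nM.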

Compound 3, inhibition constant: 1250 nM
Estimate against measurement, compound 3: 50-fold (1.70 log units) below; measured number outside the range, above it.
By their numbers in this assay, from the lowest: compound 2; then compound 1; then compound 3.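

Among these compounds, the first measured step at this place shows that it is far from indifferent to what it carries: in this assay, dimethylcarbamoyl in place of hydroxymethyl on a saturated chain carbon bound to a sulfur gives a 30-fold higher number from compound 1 to compound 3 (1.47 log units; beyond the scatter). The entering group has 5 heavy atoms and 0 hydrogen-bond donors, the leaving group 2 heavy atoms and 1 hydrogen-bond donor, and this single pair cannot tell which of these differences matters. Nothing at hand explains the size of the step.

The compounds shown leave open whether the higher number follows the carbonyl or the two methyl groups on the amide nitrogen. A primary amide, a methyl ester or a simple methoxy group at this place would each bear on that question.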